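This account rests on a few compounds, and the source may have more. Where it says the series, first, only, none or still open, it means among the compounds named here.

Compound 1 `O=C(Nc1cccc(/C=C/C(=O)c2nc3ccccc3[nH]2)c1)c1cccc(Cl)c1`: 19.5%
Compound 2 `Cc1cccc(C(=O)Nc2cccc(/C=C/C(=O)c3nc4ccccc4[nH]3)c2)c1`: 45.2%

In an assay on isolated protein for inhibition of cathepsin S (Homo sapiens), read by fluorescence, with stated times of 15 min and 30 min, tested at 5 uM (a higher number here means more inhibition at the concentration tested (going by the name of the read-out), a lower number less inhibition), compound 2 gives 45.2%, the higher of the two numbers measured; compound 1 gives 19.5%. For the measured compounds named here, the only measured step is a number 25.7 percentage points higher from compound 1 to compound 2 (beyond the scatter). Compound 3 `O=C(/C=C/c1cccc(NS(=O)(=O)c2ccccc2Cl)c1)c1nc2ccccc2[nH]1` differs from compound 2 in one place: (2-chlorophenyl)sulfonyl in place of (3-methylphenyl)carbonyl on a nitrogen on an aromatic ring. No measured step bears directly on this change, since both the amide and the ring substituent are replaced at once; the one step shown does hint that a chloro-bearing ring sat lower than a methyl-bearing one. A downward step is therefore expected, a number 20.2 percentage points lower from compound 2 to compound 3 (beyond the scatter), placing compound 3 at an estimated 25%, within a range of 5% to 50%.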

Compound 3, a percentage reported as inhibition, at one concentration (the size of the read-out at that concentration, not a potency): 45.7%
Compound 3: the middle estimate sits 20.7 percentage points below what was measured; low and high end bracket the measured number.
By their numbers in this assay, from the lowest: compound 1; then compounds 2 and 3 (each within the scatter of the next).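

In this assay, (2-chlorophenyl)sulfonyl on the nitrogen does as well as (3-methylphenyl)carbonyl (a number 0.5 percentage points higher from compound 2 to compound 3 (within the scatter)), so a sulfonyl link and a chloro-bearing ring can together match the methyl-bearing amide. Set against (3-chlorophenyl)carbonyl, the same group gives a clear gain (a number 26.2 percentage points higher from compound 1 to compound 3 (beyond the scatter)), so a chloro-bearing ring does not always go with the lower number. No measured evidence here explains either step.

As far as these compounds go, since the linking group and the ring substituent change together, their separate contributions remain open. A sulfonyl carrying 3-methylphenyl, or an amine or carboxylic acid on that ring, would help separate them.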